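Fluoro for chloro on the aromatic carbon: compound 4

The compounds below may be only part of what the source reports. "The series", "measured", "known", "first", "only" and "open" are said of these compounds alone.

Within the data shown here, compound 3 `O=C1COc2ccc(-c3nn(-c4ccc(Cl)cc4)cc3-c3ccccc3)cc2N1` gives 84.4% in a functional assay on A549 cells (Homo sapiens) for cytotoxicity, read by colorimetric assay and MTT assay, with a stated time of 3 days, tested at 1 uM (a lower number here means a stronger effect, a higher number a weaker effect of the compound at the concentration tested), the second highest of the three numbers known. Its nearest neighbour is compound 2 `O=C1COc2ccc(-c3nn(-c4ccc(Br)cc4)cc3-c3ccccc3)cc2N1`, which gives 81.5%, so that a number 2.9 percentage points higher from compound 2 to compound 3 (within the scatter). Compound 1 `Cc1ccccc1-n1cc(-c2ccccc2)c(-c2ccc3c(c2)NC(=O)CO3)n1` gives 94.8%, and a number 10.4 percentage points lower from compound 1 to compound 3 (beyond the scatter). Compound 4 `O=C1COc2ccc(-c3nn(-c4ccc(F)cc4)cc3-c3ccccc3)cc2N1` differs from compound 3 by fluoro in place of chloro on an aromatic carbon. Among the measured compounds shown here, the only measured step that bears on such a halogen exchange on the same aromatic carbon is a number 2.9 percentage points higher from compound 2 to compound 3 (within the scatter), which stayed within the scatter. A step of similar size is therefore expected, and compound 4 is expected to show a number 2.6 percentage points higher from compound 3 to compound 4 (within the scatter). Compound 4 is estimated at 87%, with a range from 77% to 97%.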

Compound 4, a percentage reported as activity, at one concentration (the size of the read-out at that concentration, not a potency): 78.2%
The estimate for compound 4 lay 8.8 percentage points above the measured number; the measured number falls inside the stated range.
By their numbers in this assay, from the lowest: compounds 4, 2 and 3 (each within the scatter of the next); then compound 1.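

In this assay, fluoro now joins chloro and bromo on this aromatic carbon, and the exchange still gives only small steps: a number 6.2 percentage points lower from compound 3 to compound 4 (within the scatter), and a number 3.3 percentage points lower from compound 2 to compound 4 (within the scatter), so no order among the three halogens can be read. The change on the aromatic nitrogen holds for this halogen too, with a number 16.6 percentage points lower from compound 1 to compound 4 (beyond the scatter). Nothing shown gives a reason for these numbers. From the compounds shown here alone, what remains open is whether an amine or a carboxylic acid on this aromatic carbon would move the number beyond the scatter.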